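Cyclopropyl to Isopropyl on a Shared Oxadiazole Ring

The compounds below may be only part of what the source reports. "The series", "measured", "known", "first", "only" and "open" are said of these compounds alone.

Three compounds have been measured in an ADME assay on H1-HeLa cells (Homo sapiens) for cytotoxicity, read by MTT assay, with a stated time of 3 days; on this read-out higher numbers stand for lower toxicity in this test and lower numbers for higher toxicity in this test:

compound 1, `CNC(=O)c1cc(Oc2ccc3c(C)c(-c4noc(C5CC5)n4)sc3c2)ccn1`, gives 6800 nM
compound 2, `CNC(=O)c1cc(Oc2ccc3c(C)c(-c4noc(C(C)C)n4)sc3c2)ccn1`, gives 5500 nM
compound 3, `CNC(=O)c1cc(Oc2ccc(-c3noc(C4CC4)n3)cc2)ccn1`, gives 32300 nM

Compound 1 and compound 2 share one core and differ in a single place: isopropyl in place of cyclopropyl on an aromatic carbon. That change produced a 1.2-fold lower number from compound 1 to compound 2 (0.09 log units; within the scatter), so the two values cannot be told apart here. Compound 3 carries a different core, and the difference between the two cores is not broken down here; what can be said is that compound 3 has the highest number of the three, with both compound 1 and compound 2 standing beyond the scatter below it.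

Compound 4, `CNC(=O)c1cc(Oc2ccc(-c3noc(C(C)C)n3)cc2)ccn1`, has not been measured. It differs from compound 3 in exactly the way compound 2 differs from compound 1: isopropyl in place of cyclopropyl on an aromatic carbon. The place is the same in both pairs, so this is the same change made on the other core.

Given that the earlier step was a 1.2-fold lower number from compound 1 to compound 2 (0.09 log units; within the scatter), the step for compound 4 is expected to be small as well, about a 1.2-fold lower number from compound 3 to compound 4 (0.06 log units; within the scatter), which rests on compound 3 at 32300 nM as the starting point. In this assay compound 4 is therefore estimated at 28000 nM, with a range expected from 14000 nM to 56000 nM.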

Compound 4, half-maximal cytotoxic concentration: 16100 nM
Compound 4: middle estimate off by 1.7-fold (0.24 log units), on the high side; the measured number falls inside the stated range.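

In this assay, isopropyl in place of cyclopropyl on the other core gave a 2.0-fold lower number from compound 3 to compound 4 (0.30 log units; within the scatter), so here too the two groups cannot be told apart. Set beside each other, the two steps do not differ by more than this test can resolve: the same change on two cores in this assay, a 1.2-fold lower number (0.09 log units; within the scatter) from compound 1 to compound 2 and a 2.0-fold lower number (0.30 log units; within the scatter) from compound 3 to compound 4, 1.6-fold (0.21 log units) apart, within the scatter of two such steps. Within the data shown here, this shows that on these two cores the change carried over without a step beyond the scatter, but it rests on only two pairs of compounds in a single cytotoxicity read-out, so it does not show that the change would read the same way on any further core or in any other test, and it gives no reason why the two groups read alike.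

The compounds shown leave open how a group of another kind on this aromatic carbon of the five-membered ring, such as an amine, a carboxylic acid or a longer chain, would read in this assay. They also leave open what a change at the other end of these molecules would do, since all four compounds carry the same methyl amide there.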